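The compounds below may be only part of what the source reports. "The series", "measured", "known", "first", "only" and "open" are said of these compounds alone.

Compound 1 `CC(C)C[C@H](NC(=O)OCc1ccccc1)C(=O)NCCNc1ccc(OC2CCCCC2)cc1` gives 1200 nM in an assay on isolated protein for inhibition of cathepsin S (Homo sapiens); a lower number here means a stronger inhibitor, a higher number a weaker inhibitor. Among the measured compounds shown here, compound 2 `CC(C)C[C@H](NC(=O)OCc1ccccc1)C(=O)NCCNc1ccc(Oc2ccccc2)cc1` gives 5800 nM in this assay, and the one measured single-point step, a 4.8-fold higher number from compound 1 to compound 2 (0.68 log units; beyond the scatter), lies beyond the scatter. Compound 3 `COc1ccc(NCCNC(=O)[C@H](CC(C)C)NC(=O)c2cccc(OC)c2)cc1` gives 470 nM in this assay, the lowest of the three numbers; its gap to compound 1 is beyond the scatter, and its gap to compound 2 is wider still. Compound 4 `COc1ccc(NCCNC(=O)[C@H](CC(C)C)NC(=O)c2cc3ccccc3[nH]2)cc1` differs from compound 3 in a single place: 1H-indol-2-yl in place of 3-methoxyphenyl on a carbonyl carbon. For the measured compounds named here, the one measured step concerns the substituent on the ether oxygen at the other end of the shared core and does not bear on an exchange at the carbonyl carbon; no measured pair tests a change of this kind, so neither direction nor size can be drawn from the numbers in hand. With nothing to guide the direction, compound 4 is expected to land near compound 3, and the step of a 1.3-fold lower number from compound 3 to compound 4 (0.13 log units; within the scatter) is estimated to stay within or close to the scatter. Compound 4 is therefore estimated at 350 nM in this assay, with a range from 70 nM to 1800 nM that reflects the absence of any bearing step.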

Compound 4, half-maximal inhibitory concentration: 160 nM
Estimate against measurement, compound 4: 2.2-fold (0.34 log units) above; the measured number falls inside the stated range.
By their numbers in this assay, from the lowest: compound 4; then compound 3; then compound 1; then compound 2.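

Among the compounds shown here, the exchange on the carbonyl carbon gives the first measured step at this position in this assay, a 2.9-fold lower number from compound 3 to compound 4 (0.47 log units; beyond the scatter), so the number here depends on the group this carbonyl carries, just as the earlier step showed for the group on the ether oxygen at the other end of the shared core. The change is not a single feature: 3-methoxyphenyl, with one six-membered aromatic ring, no hydrogen-bond donor and one acceptor, gives way to 1H-indol-2-yl, which brings a second, five-membered aromatic ring with a ring nitrogen, one donor and no acceptor, and this one pair cannot separate these differences. No measurement at hand accounts for the step.

The compounds shown leave open which of these differences carries the step, a question that groups such as 1-methylindol-2-yl, benzofuran-2-yl or plain unsubstituted phenyl on the same carbonyl carbon would address. They also leave open whether 1H-indol-2-yl would give a similar step on a core that carries cyclohexyl or phenyl on the ether oxygen.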